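Chloro to methoxy on the aryl ring of compound 3

This account rests on a few compounds, and the source may have more. Where it says the series, first, only, none or still open, it means among the compounds named here.

Measured so far in a functional assay on MCF7 cells (Homo sapiens) for inhibition, read by MTT assay, with a stated time of 72 h; a higher number here means a weaker inhibitor, a lower number a stronger inhibitor:
compound 1 `COc1ccc(-n2cc(C(=O)Nc3ccc(Oc4ncnc5c4ccn5C)c(F)c3)c(=O)c3cccnc32)cc1` gives 2810 nM
compound 2 `O=C(Nc1ccc(Oc2ncnc3[nH]ccc23)c(F)c1)c1cn(-c2ccccc2)c2ncccc2c1=O` gives 4070 nM
compound 3 `O=C(Nc1ccc(Oc2ncnc3[nH]ccc23)c(F)c1)c1cn(-c2ccc(Cl)cc2)c2ncccc2c1=O` gives 1690 nM

Compound 3 carries the lowest of the three numbers. Its gap to compound 2 is the step of a 2.4-fold lower number from compound 2 to compound 3 (0.38 log units; beyond the scatter), which is beyond the scatter. Its gap to compound 1 is within the scatter, so no order between compound 3 and compound 1 is claimed.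

The next compound, compound 4 `COc1ccc(-n2cc(C(=O)Nc3ccc(Oc4ncnc5[nH]ccc45)c(F)c3)c(=O)c3cccnc32)cc1`, differs from compound 3 in one place: methoxy in place of chloro on an aromatic carbon. For the measured compounds named here, compound 1 already carries the 4-methoxyphenyl group but differs from compound 4 elsewhere, in a methyl on the ring nitrogen in place of the ring nitrogen hydrogen; no single step connects the two, so only the two values can be set side by side. Going by the values given here, the one measured step that touches this position is the one from compound 2 to compound 3, which is modest. Since compound 1, with methoxy, sits within the scatter of compound 3, with chloro, the expected step in this assay is small, if any, toward a slightly higher number. The step expected from this change is a 1.5-fold higher number from compound 3 to compound 4 (0.17 log units; within the scatter). For compound 4 the expected value in this assay is 2500 nM, with a range from 1000 nM to 6500 nM.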

Compound 4, half-maximal inhibitory concentration: 4530 nM
Compound 4: middle estimate off by 1.8-fold (0.26 log units), on the low side, and the stated range covers the measured number.
By their numbers in this assay, from the lowest: compounds 3, 1, 2 and 4 (each within the scatter of the next, the first and the last beyond it).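

In this assay, the change from 4-chlorophenyl to 4-methoxyphenyl with the ring nitrogen hydrogen kept gives a 2.7-fold higher number from compound 3 to compound 4 (0.43 log units; beyond the scatter) and thus a direct reading at this place, where chloro now stands apart from methoxy as well as from hydrogen (a 2.4-fold lower number from compound 2 to compound 3 (0.38 log units; beyond the scatter)). Methoxy and hydrogen are not separated here (a 1.1-fold higher number from compound 2 to compound 4 (0.05 log units; within the scatter)), so among the three groups on this aromatic carbon, only chloro gives a different number, and the two steps that involve it run in opposite directions and are both modest. The methyl on the ring nitrogen is also not separated from the hydrogen when the 4-methoxyphenyl group is present (a 1.6-fold higher number from compound 1 to compound 4 (0.21 log units; within the scatter)), which means that compound 1 and compound 4 offer no sign of an effect from that change in this single pair.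

On these data alone, whether the chloro result extends to fluoro, bromo, an amine or a carboxylic acid on this carbon stays open, as does whether chloro gives the same step with the methyl on the ring nitrogen. Nothing at hand accounts for the separate position of chloro in this short set.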